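Pyrazolyl amides: from a carboxyphenyl limit to a methylpyridyl

The source may hold more compounds than are shown below. What is called first, only, known or untested is meant among the compounds shown, and "the series" means these compounds.

Compound 1 `O=C(Nc1cc(-c2ccccc2)nn1-c1ccccc1)c1cccc([N+](=O)[O-])c1`: 2220 nM
Compound 2 `COc1ccc(C(=O)Nc2cc(-c3ccccc3)nn2-c2ccccc2)cc1`: 420 nM
Compound 3 `O=C(O)c1ccc(C(=O)Nc2cc(-c3ccccc3)nn2-c2ccccc2)cc1`: > 10000 nM

In an assay on HEK293 cells for displacement of a labelled ligand from metabotropic glutamate receptor 5 (Rattus norvegicus) (on this read-out lower numbers stand for stronger inhibition and higher numbers for weaker inhibition), compound 2 gives 420 nM and compound 1 gives 2220 nM, a difference of a 5.3-fold lower number from compound 1 to compound 2 (0.72 log units; beyond the scatter). Compound 3 stands at the limit of > 10000 nM in this assay, at which 1 of the 3 values shown sits, a limit of this assay rather than a number. It stands weakest among the three, with an at least 23-fold higher number from compound 2 to compound 3 (1.37 log units; beyond the scatter) and an at least 4.5-fold higher number from compound 1 to compound 3 (0.65 log units; beyond the scatter) both beyond the scatter.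

Compound 4 `Cc1ccc(C(=O)Nc2cc(-c3ccccc3)nn2-c2ccccc2)cn1` differs from compound 3 by 6-methylpyridin-3-yl in place of 4-carboxyphenyl on a carbonyl carbon. The step from compound 2 to compound 3 bears most on this: removing the carboxy there brought a large change. Compound 4 lacks the carboxy and carries a ring resembling the aryl groups of compound 1 and compound 2, so a step downward, an at least 11-fold lower number from compound 3 to compound 4 (1.04 log units; beyond the scatter), is expected. Compound 4 is estimated at 900 nM, between 200 nM and 4500 nM.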

Compound 4, inhibition constant: 3480 nM
The estimate for compound 4 lay 3.9-fold (0.59 log units) below the measured number; low and high end bracket the measured number.
By their numbers in this assay, from the lowest: compound 2; then compounds 1 and 4 (each within the scatter of the next). At a limit, above all of these: compound 3.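

On this carbonyl carbon, 6-methylpyridin-3-yl is the only ring with a hetero atom among those shown, and in this assay it gives an at least 2.8-fold lower number from compound 3 to compound 4 (0.45 log units; beyond the scatter). Compound 3 stands at a limit, not a number: the limit of > 10000 nM in this assay, at which 1 of the 4 values shown sits. The new ring does not match 4-methoxyphenyl, with an 8.3-fold higher number from compound 2 to compound 4 (0.92 log units; beyond the scatter), and cannot be told apart from 3-nitrophenyl, with a 1.6-fold higher number from compound 1 to compound 4 (0.20 log units; within the scatter), so a ring without the carboxy does not by itself reach the 4-methoxyphenyl level.

Open, as far as these compounds go, is whether the ring nitrogen or the methyl carries the step from 4-methoxyphenyl. An unsubstituted pyridyl or a 4-methylphenyl would separate the two.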